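From a benzyl ether to a butyl ether on the shared core

This account rests on a few compounds, and the source may have more. Where it says the series, first, only, none or still open, it means among the compounds named here.

Of the compounds shown here, three built on one shared core have been measured in a functional assay on KB cells (Homo sapiens) for cytotoxicity, read by MTT assay, with a stated time of 72 h; on this read-out lower numbers stand for stronger inhibition and higher numbers for weaker inhibition. Compound 1 `O=[N+]([O-])c1cccc(COCNc2n[n+]([O-])c3ccccc3[n+]2[O-])c1` gives 580 nM. Compound 2 `[O-][n+]1nc(NCOCc2ccccc2)[n+]([O-])c2ccccc21` gives 5720 nM, and compound 3 `CC(OCNc1n[n+]([O-])c2ccccc2[n+]1[O-])c1ccccc1` gives 2510 nM. Compound 2 therefore carries the highest number of the three: the step of a 9.9-fold higher number from compound 1 to compound 2 (0.99 log units; beyond the scatter) accompanies the loss of the nitro group, while the step of a 2.3-fold lower number from compound 2 to compound 3 (0.36 log units; beyond the scatter) follows the arrival of a methyl on the saturated chain carbon.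

Compound 4 `CCCCOCNc1n[n+]([O-])c2ccccc2[n+]1[O-]` differs from compound 2 in one place: propyl in place of phenyl on a saturated chain carbon bound to an oxygen on a saturated carbon. Among the measured compounds shown here, neither measured step replaces the phenyl at this position, so no step bears directly on the change. The closest comparison is the step from compound 2 to compound 3, which touched the same saturated chain carbon and shifted the number only modestly. The direction of exchanging a phenyl for a propyl cannot be read from the three values, so the number for compound 4 is expected to stay close to that of compound 2. The expected step is a 1.2-fold higher number from compound 2 to compound 4 (0.09 log units; within the scatter). Compound 4 is estimated at 7000 nM, within a range from 2500 nM to 20000 nM.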

Compound 4, half-maximal inhibitory concentration: 1750 nM
Compound 4: middle estimate off by 4.0-fold (0.60 log units), on the high side; the whole stated range lies above it.
By their numbers in this assay, from the lowest: compound 1; then compounds 4 and 3 (each within the scatter of the next); then compound 2.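

In this assay, among the compounds shown here, this is the first change that removes the phenyl itself, and it gives a 3.3-fold lower number from compound 2 to compound 4 (0.51 log units; beyond the scatter). The number therefore falls beyond the scatter when the six-membered aromatic ring of carbon only gives way to a ringless propyl with 3 heavy atoms in place of 6, so an aromatic ring at this place is not needed for a lower number among the compounds shown. Compound 2 now stands above each of the other three compounds, on steps that all lie beyond the scatter, yet nothing available explains why this exchange lowers the number.

For the compounds shown here, the single pair cannot separate the loss of the ring from the gain of the flexible chain, and a cyclohexyl at the same place would be needed to tell the two apart. On these data alone, how the number responds to a shorter chain such as ethyl, a longer chain such as hexyl, or an amine at the end of the chain also remains open.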